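This account rests on a few compounds, and the source may have more. Where it says the series, first, only, none or still open, it means among the compounds named here.

Measured in an in vitro ADME assay on microsomes from liver (Mus musculus) for metabolic stability, tested at 0.2 uM; on this read-out lower numbers stand for slow clearance and higher numbers for fast clearance:
- compound 1 `COCCOCCCCc1[nH]c2ccccc2c(=O)c1C` with > 1000 mL/min/kg as a limit of the assay
- compound 2 `CCCCOc1cccc(OCc2[nH]c3ccccc3c(=O)c2C)c1` with > 1000 mL/min/kg as a limit of the assay
- compound 3 `Cc1c(COc2cc(OCC3CCOCC3)ccn2)[nH]c2ccccc2c1=O` with 312 mL/min/kg as a measured number

The set so far is dominated by the limit of > 1000 mL/min/kg in this assay, at which 2 of the 3 values shown sit, in its readings. Among the measured compounds shown here, compound 3 gives 312 mL/min/kg as the only true number of the three, so it alone has a clearance that can be read as a value, and it lies on the slower side of the other two.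

Compound 4 `Cc1c(COc2cc(OCCC(C)(C)O)ccn2)[nH]c2ccccc2c1=O` keeps the shared core and alters one group. The change is 2-hydroxy-2-methylpropyl in place of oxan-4-yl on a saturated chain carbon bound to an oxygen on an aromatic ring as counted between the two structures. Put simply, 2-hydroxy-2-methylpropyl stands in place of oxan-4-yl on a saturated chain carbon bound to an oxygen on an aromatic ring, so the ring leaves and a hydrogen-bond donor enters.

For the measured compounds named here, no measured pair in the set shows this kind of exchange, so any expectation here is loose. Going by the values given here, it rests on compound 3 at 312 mL/min/kg as the single starting number. The estimated change is a 2.1-fold lower number from compound 3 to compound 4 (0.32 log units; beyond the scatter) in the direction of slower clearance, which would be a modest expected step. For compound 4 the expected clearance is 150 mL/min/kg with an estimated range from 60 mL/min/kg to 400 mL/min/kg in this read-out.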

Compound 4, clearance in the liver assay: 112 mL/min/kg
Estimate against measurement, compound 4: 1.3-fold (0.13 log units) above; measured number inside the range.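

Among the compounds shown here, in the liver assay, 2-hydroxy-2-methylpropyl in place of oxan-4-yl on a saturated chain carbon bound to an oxygen on an aromatic ring gives a 2.8-fold lower number from compound 3 to compound 4 (0.44 log units; beyond the scatter), the first step in this set that can be read, and it shows that clearance responds to a change at this position. The same pair also differs in a physicochemical assay for solubility, at pH 6.8 (on this read-out higher numbers stand for higher solubility and lower numbers for lower solubility), so this single exchange goes with slower clearance and with higher solubility together: the measured solubility of compound 3, 36000 nM, and of compound 4, 85000 nM, a 2.4-fold higher number (0.37 log units; beyond the scatter). In the physicochemical assay compound 3 gives 36000 nM and compound 4 gives 85000 nM. Before this pair, no two compounds differed in just one place, and much of the set rested on a limit of the assay: the limit of > 1000 mL/min/kg in the liver assay, at which 2 of the 4 values shown sit.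

This is still one pair, so it cannot separate the loss of the ring from the arrival of the hydroxyl group, and a plain 3-methylbutyl chain, without the hydroxyl group, would be the natural comparison. From the compounds shown here alone, it also remains open whether an amine or a carboxylic acid at the end of this chain would follow the same direction, and whether the step would hold on any other core.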